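Swapping the anilide aryl group for a pyridine ring

The compounds below may be only part of what the source reports. "The series", "measured", "known", "first", "only" and "open" are said of these compounds alone.

Measured compounds:
compound 1 `CN1C[C@H](C(=O)Nc2ccc(F)cc2)[C@@H](c2ccc(/C=C/C(=O)Nc3ccccc3N)cc2)C1`, 34 mL/min/kg
compound 2 `CN1C[C@H](C(=O)Nc2ccc(Br)cc2)[C@@H](c2ccc(/C=C/C(=O)Nc3ccccc3N)cc2)C1`, 16 mL/min/kg
compound 3 `CN1C[C@H](C(=O)Nc2cccc(Cl)c2)[C@@H](c2ccc(/C=C/C(=O)Nc3ccccc3N)cc2)C1`, 58 mL/min/kg

The three compounds share one core and differ only in the aryl group on the amide-type nitrogen. In an in vitro ADME assay on microsomes from liver (Mus musculus) for pharmacokinetics, read by LC-MS, with a stated time of 10 min, tested at 1 uM (on this read-out lower numbers stand for slow clearance and higher numbers for fast clearance), compound 3 gives 58 mL/min/kg, the highest of the three numbers. One measured step is a 1.7-fold higher number from compound 1 to compound 3 (0.23 log units; within the scatter), whereas the other step ending there is a 3.6-fold higher number from compound 2 to compound 3 (0.56 log units; beyond the scatter). The other measured step, a 2.1-fold lower number from compound 1 to compound 2 (0.33 log units; beyond the scatter), points the same way as the bromo compound being the slowest cleared of the three.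

Compound 4 `CN1C[C@H](C(=O)Nc2cccnc2)[C@@H](c2ccc(/C=C/C(=O)Nc3ccccc3N)cc2)C1` is obtained from compound 3 by the change (pyridin-3-yl in place of 3-chlorophenyl on an amide-type nitrogen). Within the data shown here, no measured step involves a pyridin-3-yl group, so the two steps that end at compound 3 give only a sense of scale: changes among halogenated phenyl groups moved this read-out by amounts near or somewhat beyond the scatter. On that basis compound 4 is expected to sit at a somewhat lower number than compound 3, a step of about a 1.7-fold lower number from compound 3 to compound 4 (0.22 log units; within the scatter), with the real possibility that it falls within the scatter. The estimate for compound 4 in this assay is 35 mL/min/kg, with a range from 15 mL/min/kg to 80 mL/min/kg.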

Compound 4, clearance: 41 mL/min/kg
Compound 4: middle estimate off by 1.2-fold (0.07 log units), on the low side; the range from low to high includes it.
By their numbers in this assay, from the lowest: compound 2; then compounds 1, 4 and 3 (each within the scatter of the next).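

In this assay, among these compounds, the pyridin-3-yl group, the only aryl group here with a hetero atom in its ring and the only one with a hydrogen-bond acceptor, gives a 1.4-fold lower number from compound 3 to compound 4 (0.15 log units; within the scatter) and a 1.2-fold higher number from compound 1 to compound 4 (0.08 log units; within the scatter), so at this position it cannot be told apart from the 3-chlorophenyl or the 4-fluorophenyl group. Only the 4-bromophenyl group stands apart, with a 2.6-fold higher number from compound 2 to compound 4 (0.41 log units; beyond the scatter), which shows that on this amide-type nitrogen an aryl group need not carry a halogen to give a number in the range of compound 1 and compound 3, while compound 2 remains the lowest of the four. Nothing at hand explains why the ring nitrogen leaves the number so close to those of compound 1 and compound 3.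

The compounds shown leave open whether pyridin-2-yl or pyridin-4-yl would behave like pyridin-3-yl on this nitrogen, and whether a bromopyridinyl group would bring the low number of compound 2 onto the pyridine ring. They also leave open what a saturated ring such as piperidinyl, or a plain alkyl chain, would do here.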